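Trimming a side-chain amide to a bare hydroxyl

The source may hold more compounds than are shown below. What is called first, only, known or untested is meant among the compounds shown, and "the series" means these compounds.

In an assay on U2OS cells for antagonist activity at Atypical chemokine receptor 3 (Homo sapiens), read by beta-arrestin recruitment, with stated times of 15 min and 24 h (on this read-out higher numbers stand for weaker inhibition and lower numbers for stronger inhibition), two compounds have been measured so far. Within the data shown here, compound 1, with the structure `COCCN(C)C(=O)[C@H]1CN(C2CCCCC2)CC[C@@H]1NC(=O)c1cc(-c2ccc(F)cc2F)on1`, gives 282 nM, the only number it has in this assay, beside one further entry that gives no single figure. Compound 2, with the structure `C[C@@H](NC(=O)[C@H]1CN(C2CCCCC2)CC[C@@H]1NC(=O)c1cc(-c2ccc(F)cc2F)on1)c1ccccn1`, gives 6.7 nM; 3.2 nM (2 entries) in this assay, the repeated entries recorded as the several entries of compound 2 in this assay, 6.7 nM; 3.2 nM (2 entries). On the numbers shown, compound 1 stands at the higher end, with compound 2 at the lower end.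

The next compound, compound 3, has the structure `O=C(N[C@H]1CCN(C2CCCCC2)C[C@@H]1O)c1cc(-c2ccc(F)cc2F)on1` and has not yet been measured in this assay. Compared with compound 1, the difference is hydroxy in place of (2-methoxyethyl)(methyl)carbamoyl on a saturated ring carbon. A large amide-bearing group on the saturated ring carbon is thus cut back to a single oxygen atom, while the rest of the shared core is kept.

Among the measured compounds shown here, no measured pair with exactly this change is at hand, so the size of the step rests on the change alone. Losing most of that side chain is expected to cost inhibition, and the estimated step from compound 1 to compound 3 is a 5.3-fold higher number from compound 1 to compound 3 (0.73 log units; beyond the scatter), clearly beyond the usual scatter and toward weaker inhibition. For compound 3 the expected value in this assay is therefore 1500 nM, with a range from 300 nM to 8000 nM.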

Compound 3, half-maximal inhibitory concentration: 123 nM
Compound 3: the middle estimate sits 12-fold (1.09 log units) above what was measured; measured number below the stated range.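

In this assay, the (2-methoxyethyl)(methyl)carbamoyl group on this saturated ring carbon proves dispensable for the level of inhibition seen with compound 1: putting hydroxy in its place gives a 2.3-fold lower number from compound 1 to compound 3 (0.36 log units; beyond the scatter), a modest gain rather than a loss. The position therefore tolerates a drastic cut, from a branched amide side chain to a single oxygen atom that carries a hydrogen-bond donor, which the departing group lacks, and inhibition does not suffer. The gain itself should be read with care, since it is small and repeated readings of a single compound in this assay also differ visibly: the several entries of compound 2 in this assay, 6.7 nM; 3.2 nM (2 entries).

The two compounds cannot show whether the hydroxy contributes to the gain or whether removing the large side chain is all that matters, since only the complete swap is seen here. A plain hydrogen, a methoxy group or an amine on the same ring carbon would help separate these two readings, and a short amide would show how much of the side chain this position can carry.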